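Three Limits on the Shared Core, Then a 3-Fluorobutyl Chain

This account rests on a few compounds, and the source may have more. Where it says the series, first, only, none or still open, it means among the compounds named here.

Compound 1 `Cn1c(-c2ccccc2C(F)(F)F)nnc1C12CCC(CCCC(C)(F)F)(CC1)CC2` gives in an assay on CHO-K1 cells for inhibition of 11-beta-hydroxysteroid dehydrogenase type 2 (Homo sapiens), read by scintillation proximity assay (on this read-out lower numbers stand for stronger inhibition and higher numbers for weaker inhibition), only a limit, > 4000 nM.
Compound 2 `Cn1c(-c2ccccc2C(F)(F)F)nnc1C12CCC(COc3ccc(S(C)(=O)=O)cc3)(CC1)CC2` gives in this assay only a limit, > 4000 nM.
Compound 3 `CCOCC12CCC(c3nnc(-c4ccccc4C(F)(F)F)n3C)(CC1)CC2` gives in this assay only a limit, > 4000 nM.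

Compound 3 thus stands at the limit of this assay, not at a number, and the two other values shown are limits as well; all three sit at the limit of > 4000 nM in this assay, at which 3 of the 3 values shown sit. None of the steps between them can be read: the step that the two limits leave unreadable from compound 1 to compound 2 is unreadable, as are the steps a step that the two limits leave unreadable from compound 1 to compound 3 and a step that the two limits leave unreadable from compound 2 to compound 3.

Compound 4 `CC(F)CCCC12CCC(c3nnc(-c4ccccc4C(F)(F)F)n3C)(CC1)CC2` differs from compound 3 in one place: 3-fluorobutyl in place of ethoxy on a saturated chain carbon bound to a saturated ring carbon. The chain that enters in compound 4 resembles the chain of compound 1 in that both carry fluorine on a saturated carbon chain, and compound 1 sits at the limit. The measured steps therefore give no direction and no size for this assay; what they show is that every change of this group so far left the read-out at the limit.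

Compound 4 is therefore expected to remain at the limit of this assay as well, with the step that the limit leaves unreadable from compound 3 to compound 4 estimated as not readable. Compound 4 is estimated at 8000 nM, between 2000 nM and 40000 nM.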

Compound 4, half-maximal inhibitory concentration: 1300 nM
Compound 4: middle estimate off by 6.2-fold (0.79 log units), on the high side; the measured number lies below the stated range.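

With 3-fluorobutyl on the saturated chain carbon bound to a saturated ring carbon, the shared core gives its first number in this assay and so shows that this read-out can respond to the group at this place: the change gives an at least 3.0-fold lower number from compound 3 to compound 4 (0.48 log units; beyond the scatter) and, with 3-fluorobutyl in place of 4-(methylsulfonyl)phenoxy, an at least 3.0-fold lower number from compound 2 to compound 4 (0.48 log units; beyond the scatter) whereas the steps among compound 1, compound 2 and compound 3 cannot be read. The closest comparison is an at least 3.0-fold lower number from compound 1 to compound 4 (0.48 log units; beyond the scatter) in which hydrogen takes the place of fluoro on a saturated chain carbon bound to a fluorine atom and two saturated chain carbons, so a change this small is enough to bring the read-out off the limit. The number of compound 4 stands alone against one shared limit: the limit of > 4000 nM in this assay, at which 3 of the 4 values shown sit.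

On these data alone, each of these steps is open on one side, so the full size of each remains unknown. As far as these compounds go, whether a plain butyl chain would read like 3-fluorobutyl stays open, as does how a longer chain or an amine would read at this place.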